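Urea to amide: estimating compound 4 on cytotoxicity

A few compounds are considered here, and "the series" means these few. Any claim that something is new, unique, unknown or untested is made for them only; others in the source may bear on it.

Compound 1 `O=C(NCCCCC(c1ccc(F)cc1)c1ccc(F)cc1)Nc1cccc(C(F)(F)F)c1`: 3380 nM
Compound 2 `O=C(NCCCCC(c1ccc(F)cc1)c1ccc(F)cc1)Nc1ccc([N+](=O)[O-])c(C(F)(F)F)c1`: 4550 nM
Compound 3 `O=C(NCCCCC(c1ccc(F)cc1)c1ccc(F)cc1)Nc1ccc(C(=O)O)c(C(F)(F)F)c1`: > 20000 nM

In a functional assay on MDA-MB-231 cells (Homo sapiens) for cytotoxicity, read by MTT assay, with a stated time of 48 h (on this read-out lower numbers stand for stronger inhibition and higher numbers for weaker inhibition), compound 1 gives 3380 nM, the lowest of the two numbers shown. Compound 2, with nitro in place of hydrogen on an aromatic carbon, gives 4550 nM, a step of a 1.3-fold higher number from compound 1 to compound 2 (0.13 log units; within the scatter). Compound 3 reaches only the limit (the limit of > 20000 nM in this assay, at which 1 of the 3 values shown sits), so the steps of an at least 5.9-fold higher number from compound 1 to compound 3 (0.77 log units; beyond the scatter) and an at least 4.3-fold higher number from compound 2 to compound 3 (0.64 log units; beyond the scatter) are at least modest.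

Compound 4 `O=C(NCCCCC(c1ccc(F)cc1)c1ccc(F)cc1)c1ccc(Cl)c(C(F)(F)F)c1` differs from compound 1 at the carbonyl carbon: 4-chloro-3-(trifluoromethyl)phenyl in place of (3-(trifluoromethyl)phenyl)amino on a carbonyl carbon. Among the measured compounds shown here, none of the measured steps changes this part of the core; they all vary substituents on the aromatic ring. For the measured compounds named here, no step therefore bears directly on this change, and no shift beyond the scatter is expected. Compound 4 is estimated at 3500 nM, between 1100 nM and 11000 nM, a step of a 1.0-fold higher number from compound 1 to compound 4 (0.02 log units; within the scatter).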

Compound 4, half-maximal inhibitory concentration: 11700 nM
The estimate for compound 4 lay 3.3-fold (0.52 log units) below the measured number, outside the stated range (above it).
By their numbers in this assay, from the lowest: compounds 1 and 2 (each within the scatter of the next); then compound 4. At a limit, above all of these: compound 3.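

In this assay, among the compounds shown here, the change at the carbonyl carbon gives a 3.5-fold higher number from compound 1 to compound 4 (0.54 log units; beyond the scatter), so this part of the core, which the earlier steps left untouched, does move the read-out. The step exchanges the amino nitrogen, with its hydrogen-bond donor, for a direct aryl link and also brings in chlorine, and it cannot separate these two changes. Nothing measured here gives a cause for the shift.

Still open, going by these compounds, is whether 4-chloro-3-(trifluoromethyl)phenyl attached through the amino nitrogen would behave like compound 1 or compound 4. Also open, on these data alone, is how an ether oxygen or a methylene in place of that nitrogen would read.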